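A few compounds are considered here, and "the series" means these few. Any claim that something is new, unique, unknown or untested is made for them only; others in the source may bear on it.

Compound 3 `O=S(=O)(NCCCCNCc1ccc(Br)cc1)c1cc(C(F)(F)F)cc(C(F)(F)F)c1` gives 2200 nM in a functional assay on PANC-1 cells (Homo sapiens) for inhibition, read by MTT assay, with a stated time of 72 h (a lower number here means a stronger inhibitor of growth, a higher number a weaker inhibitor of growth), the lowest of the three numbers obtained so far. Compound 1 `O=S(=O)(NCCCNCc1cccc2ccccc12)c1cc(C(F)(F)F)cc(C(F)(F)F)c1` gives 2700 nM in this assay, which lies within the scatter of the value of compound 3, so the two cannot be ranked against each other. Compound 2 `CC(C)(C)c1ccc(CNCCNS(=O)(=O)c2cc(C(F)(F)F)cc(C(F)(F)F)c2)cc1` gives 13000 nM in this assay, a gap from compound 3 that lies beyond the scatter.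

Among the measured compounds shown here, compound 4 `O=S(=O)(NCCCNCc1ccc(Cl)cc1)c1cc(C(F)(F)F)cc(C(F)(F)F)c1` differs from compound 3 in one place: (4-chlorobenzyl)amino in place of ((4-bromobenzyl)amino)methyl on a saturated chain carbon, three bonds along the chain from a sulfonamide nitrogen No measured pair isolates this change. A shift from compound 3 to compound 4 in this assay is expected to be small, at most a modest move toward a higher number, and the value of compound 4 is estimated at 3000 nM with a range of 1500 nM to 7000 nM, meaning a step of a 1.4-fold higher number from compound 3 to compound 4 (0.13 log units; within the scatter).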

Compound 4, concentration for 50% growth inhibition: 4900 nM
For compound 4 the middle estimate is 1.6-fold (0.21 log units) below the measured one, and the stated range covers the measured number.
By their numbers in this assay, from the lowest: compounds 3, 1 and 4 (each within the scatter of the next, the first and the last beyond it); then compound 2.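

In this assay, among the compounds shown here, (4-chlorobenzyl)amino in place of ((4-bromobenzyl)amino)methyl gives a 2.2-fold higher number from compound 3 to compound 4 (0.35 log units; beyond the scatter), a modest step beyond the scatter, the first readable change at this place. By contrast, 4-chlorophenyl in place of naphthalen-1-yl gives a 1.8-fold higher number from compound 1 to compound 4 (0.26 log units; within the scatter), within the scatter, so these two groups cannot be ranked. No available evidence bears on either step.

The exchange swaps bromine for chlorine and also loses one carbon, and these compounds do not separate the two. As far as these compounds go, how a 4-fluorobenzyl group or a longer chain would read remains open.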